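Benzyl amine variation on a bis(trifluoromethyl)benzenesulfonamide chain

The source may report more compounds than this note shows. Statements on the series, on what has been measured and on what is new or still open speak of the compounds shown alone.

Measured compounds:
compound 1 `O=S(=O)(NCCCCNCc1ccc(Br)cc1)c1cc(C(F)(F)F)cc(C(F)(F)F)c1` gives 1500 nM
compound 2 `COc1ccc(CNCCCNS(=O)(=O)c2cc(C(F)(F)F)cc(C(F)(F)F)c2)cc1OC` gives 1900 nM
compound 3 `O=S(=O)(NCCCNCC1COc2ccccc2O1)c1cc(C(F)(F)F)cc(C(F)(F)F)c1` gives 2500 nM

In a functional assay on MCF7 cells (Homo sapiens) for inhibition, read by MTT assay, with a stated time of 72 h (a higher number here means a weaker inhibitor of growth, a lower number a stronger inhibitor of growth), compound 3 has the highest of the three numbers. Going by the values given here, its nearest neighbour is compound 2, and the only single-point step so far is a 1.3-fold higher number from compound 2 to compound 3 (0.12 log units; within the scatter), which is within the scatter. Compound 1 also sits within the scatter of compound 3, so none of the three can be set apart from the others.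

Compound 4 `COc1ccccc1CNCCCNS(=O)(=O)c1cc(C(F)(F)F)cc(C(F)(F)F)c1` differs from compound 3 by 2-methoxyphenyl in place of 2,3-dihydro-1,4-benzodioxin-2-yl on a saturated chain carbon bound to an amine nitrogen. Among the compounds with values here, the one step that bears on this position, from compound 2 to compound 3, exchanged one aryl group for another on the same saturated chain carbon and gave a change within the scatter; compound 1 carries yet another aryl group there with a similar number. On this basis compound 4 is expected to show a step of a 1.3-fold lower number from compound 3 to compound 4 (0.10 log units; within the scatter), that is, nothing beyond the scatter in this assay. The estimate for compound 4 in this assay is 2000 nM, with a range from 1000 nM to 4200 nM.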

Compound 4, concentration for 50% growth inhibition: 2600 nM
Beside the measured number, compound 4's estimate is 1.3-fold (0.11 log units) below it; low and high end bracket the measured number.
By their numbers in this assay, from the lowest: compounds 1, 2, 3 and 4 (each within the scatter of the next).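

In this assay the exchange of 2,3-dihydro-1,4-benzodioxin-2-yl for 2-methoxyphenyl on a saturated chain carbon bound to an amine nitrogen gives a 1.0-fold higher number from compound 3 to compound 4 (0.02 log units; within the scatter) and so shows that the non-aromatic ring of the leaving group can go without a change beyond the scatter. The same holds for 2-methoxyphenyl in place of 3,4-dimethoxyphenyl, which gives a 1.4-fold higher number from compound 2 to compound 4 (0.14 log units; within the scatter) and for the wider change of (2-methoxybenzyl)amino in place of ((4-bromobenzyl)amino)methyl, which gives a 1.7-fold higher number from compound 1 to compound 4 (0.24 log units; within the scatter) and leaves this position flat across all four compounds. No measurement at hand explains this result.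

Going by these compounds, whether a pyridine or a carboxylic acid at this position would move the number beyond the scatter remains open. So does the effect of a plain methyl group there, or of a longer chain.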